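The source may hold more compounds than are shown below. What is called first, only, known or untested is meant among the compounds shown, and "the series" means these compounds.

Three compounds have so far been measured in a functional assay on HeLa cells (Homo sapiens) for antiproliferative activity, read by CCK-8 assay, with a stated time of 72 h, tested at 8 uM; on this read-out higher numbers stand for a stronger effect at the one concentration tested and lower numbers for a weaker effect:

Compound 1, `Nc1ccccc1NC(=O)c1ccc(CSC(=S)N2CCc3ccccc32)cc1`, gives 67%.
Compound 2, `Nc1ccccc1NC(=O)c1ccc(CSC(=S)N2CCc3cc(Cl)ccc32)cc1`, gives 65.1%.
Compound 3, `CC1CCN(C(=S)SCc2ccc(C(=O)Nc3ccccc3N)cc2)CC1`, gives 72.5%.

Compound 2 holds the lowest of these three numbers, yet this says little: its nearest neighbour is compound 1, separated by a number 1.9 percentage points lower from compound 1 to compound 2 (within the scatter), and the gap to compound 3 is a number 7.4 percentage points higher from compound 2 to compound 3 (within the scatter), both within the scatter, so no order among the three can be claimed.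

Compound 4, `COC(=O)c1ccc2c(c1)CCN2C(=S)SCc1ccc(C(=O)Nc2ccccc2N)cc1`, differs from compound 2 in one place: methoxycarbonyl in place of chloro on an aromatic carbon. The step that bears most directly on this is the earlier change on an aromatic carbon of the same fused system, from compound 1 to compound 2, which gave a number 1.9 percentage points lower from compound 1 to compound 2 (within the scatter). The remaining steps alter the group on the thiocarbonyl carbon instead and gave a number 5.5 percentage points higher from compound 1 to compound 3 (within the scatter) and a number 7.4 percentage points higher from compound 2 to compound 3 (within the scatter), again within the scatter. Every change tried so far, at either end of the shared core, has left this assay essentially unmoved, so the expected step is a number 0.9 percentage points higher from compound 2 to compound 4 (within the scatter), with no move beyond the scatter in either direction. Compound 4 is therefore estimated at 66%, within a range from 50% to 80%.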

Compound 4, a percentage reported as inhibition, at one concentration (the size of the read-out at that concentration, not a potency): 60.1%
For compound 4 the middle estimate is 5.9 percentage points above the measured one; the range from low to high includes it.
By their numbers in this assay, from the lowest: compounds 4, 2, 1 and 3 (each within the scatter of the next, the first and the last beyond it).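

This aromatic carbon of the shared core has now carried hydrogen, chloro and methoxycarbonyl, and the last differs far more from the first two than chloro does from hydrogen: it has 4 heavy atoms where chloro has 1, and it brings 2 hydrogen-bond acceptors and a double bond outside aromatic rings. Even so, in this assay the exchange for chloro gives a number 5 percentage points lower from compound 2 to compound 4 (within the scatter), and the exchange for hydrogen gives a number 6.9 percentage points lower from compound 1 to compound 4 (within the scatter), so a substantially larger group at this position still cannot be told apart from the smaller ones on this read-out. Nothing available explains this result at the position.

It remains open whether an amine, a carboxylic acid or a longer chain on this same aromatic carbon would also stay within the scatter of these compounds. As far as these compounds go, since the read-out gives the size of the effect at a single concentration, it also remains open whether compounds that cannot be separated here would match in potency.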